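Thiosemicarbazones of a quinoline aldehyde: a ring-substituent swap

The source may report more compounds than this note shows. Statements on the series, on what has been measured and on what is new or still open speak of the compounds shown alone.

Compound 1 `S=C(NCc1ccccc1)N/N=C/c1ccc2ccccc2n1`: 53700 nM
Compound 2 `NC(=S)N/N=C/c1ccc2ccccc2n1`: 32700 nM
Compound 3 `COc1cccc(NC(=S)N/N=C/c2ccc3ccccc3n2)c1`: 79400 nM

In a functional assay on SGC-7901 cells (Homo sapiens) for antiproliferative activity, read by sulforhodamine B assay, with a stated time of 72 h (a lower number here means a stronger inhibitor, a higher number a weaker inhibitor), compound 3 gives the highest of the three numbers; its nearest neighbour is compound 1, and the step of a 1.5-fold higher number from compound 1 to compound 3 (0.17 log units; within the scatter) lies within the scatter, while a 2.4-fold higher number from compound 2 to compound 3 (0.39 log units; beyond the scatter) is modest but beyond it. Compound 4 `Cc1ccccc1NC(=S)N/N=C/c1ccc2ccccc2n1` differs from compound 3 by 2-methylphenyl in place of 3-methoxyphenyl on an amide-type nitrogen. Within the data shown here, the steps that bear on this change are the two that alter the same nitrogen, a 1.6-fold lower number from compound 1 to compound 2 (0.22 log units; within the scatter) and a 1.5-fold higher number from compound 1 to compound 3 (0.17 log units; within the scatter), both small, and a 2.4-fold higher number from compound 2 to compound 3 (0.39 log units; beyond the scatter). An aryl-for-aryl exchange there is therefore expected to move this assay little, at most a slight decrease, a 1.3-fold lower number from compound 3 to compound 4 (0.12 log units; within the scatter). Compound 4 is estimated at 60000 nM, with a range of 25000 nM to 150000 nM.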

Compound 4, half-maximal inhibitory concentration: > 100000 nM
Compound 4 ended at the assay's limit (the forecaster's own chance of this, stated with the estimate: 10%); middle value at least 1.6-fold (0.22 log units) from the limit.
By their numbers in this assay, from the lowest: compounds 2, 1 and 3 (each within the scatter of the next, the first and the last beyond it). At a limit, above all of these: compound 4.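

Compound 4 stands at a limit of the assay, not at a number: the limit of > 100000 nM in this assay, at which 1 of the 4 values shown sits. Placing 2-methylphenyl instead of hydrogen on this amide-type nitrogen gives an at least 3.0-fold higher number from compound 2 to compound 4 (0.48 log units; beyond the scatter), so a second aryl group moves the number the same way as 3-methoxyphenyl. On these data alone, the other two steps, an at least 1.2-fold higher number from compound 3 to compound 4 (0.10 log units; that floor lies within the scatter) and an at least 1.8-fold higher number from compound 1 to compound 4 (0.27 log units; that floor lies within the scatter), are floors only, and their true size stays unknown.

As far as these compounds go, it remains open whether an amine or a carboxylic acid on the aryl group, or a longer chain in place of benzyl, would give a lower number than hydrogen on this nitrogen.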